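Replacing the amino group on the core with methyl

The source may report more compounds than this note shows. Statements on the series, on what has been measured and on what is new or still open speak of the compounds shown alone.

Measured so far:
compound 1, `C/N=C(\S)n1ncnc1N`, 93%
compound 2, `C/N=C(\S)n1nc(N)nc1N`, 53%

In a functional assay on the whole organism for inhibition, with Rattus norvegicus as the target, at a dose of 30 mg/kg (a lower number here means less inhibition, a higher number more inhibition at the dose given (going by the name of the read-out)), compound 1 gives 93%, and compound 2 gives 53%. Compound 2 stands lowest of the two numbers measured; the step of a number 40 percentage points lower from compound 1 to compound 2 (beyond the scatter) is the only one known, and it is amino in place of hydrogen on an aromatic carbon.

Compound 3, `C/N=C(\S)n1nc(C)nc1N`, has not yet been measured in this assay. It differs from compound 2 by methyl in place of amino on an aromatic carbon.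

For the measured compounds named here, the one known step bears on this change only in part: it shows that adding an amino group at this place lowered the number, so taking the amino group away again might recover some of it, but methyl is not hydrogen, and no step with methyl at this carbon is known. The expectation is therefore for compound 3 to lie between the two measured numbers, closer to compound 1 than compound 2 is, with a wide range.

Compound 3 is estimated at 75%, in a range from 45% to 95%, which is expected to mean a step of a number 22 percentage points higher from compound 2 to compound 3 (beyond the scatter).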

Compound 3, a percentage reported as inhibition, in the whole organism at one dose (the size of the read-out at that dose, not a potency): 13%
Compound 3: middle estimate off by 62 percentage points, on the high side; measured number below the stated range.
By their numbers in this assay, from the lowest: compound 3; then compound 2; then compound 1.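

In this assay, the aromatic carbon between two ring nitrogen atoms now carries three different groups across the series, and taking amino away does not bring the number back toward that of compound 1: methyl in place of amino gives a number 40 percentage points lower from compound 2 to compound 3 (beyond the scatter) and so the change runs further down rather than back up. Set against hydrogen on the same carbon, methyl gives a number 80 percentage points lower from compound 1 to compound 3 (beyond the scatter) and this makes the order hydrogen, then amino, then methyl from high to low, so the fall seen with amino is not peculiar to amino, and neither group placed here keeps the number of compound 1. What lies behind this order is not shown by anything available here.

The three compounds leave open how other groups on this carbon would read, such as ethyl, chlorine, hydroxyl or a carboxylic acid, and whether any group other than hydrogen can hold the number up. They also leave open whether the hydrogen-bond donor and acceptor counted on amino, and absent from methyl, have any part in the gap, and how the three compounds would compare at other doses.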